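The source may report more compounds than this note shows. Statements on the series, on what has been measured and on what is new or still open speak of the compounds shown alone.

Compound 1 `C[C@H](O)[C@@H](CCc1cccc(Br)c1)n1cnc2c(N)ncnc21` — 0.6 nM
Compound 2 `C[C@H](O)[C@@H](CCc1cccc(C(N)=O)c1)n1cnc2c(N)ncnc21` — 2.9 nM

In an assay on isolated protein for inhibition of adenosine deaminase (Bos taurus), with a stated time of 5 min (on this read-out lower numbers stand for stronger inhibition and higher numbers for weaker inhibition), compound 2 gives 2.9 nM, the higher of the two numbers; compound 1 sits at 0.6 nM, and the step of a 4.8-fold higher number from compound 1 to compound 2 (0.68 log units; beyond the scatter) separates them. Compound 3 `CNC(=O)c1cccc(CC[C@H]([C@H](C)O)n2cnc3c(N)ncnc32)c1` differs from compound 2 by methyl in place of hydrogen on an amide-type nitrogen. Among the measured compounds shown here, no measured step touches this amide nitrogen; the single known step concerns the ring substituent, so it says little about adding a methyl here. A change that small is expected to move the number within the scatter, perhaps slightly upward, giving an estimated step of a 1.4-fold higher number from compound 2 to compound 3 (0.14 log units; within the scatter). Compound 3 is therefore estimated at 4 nM, expected between 1.5 nM and 12 nM.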

Compound 3, inhibition constant: 2.7 nM
Compound 3: the middle estimate sits 1.5-fold (0.17 log units) above what was measured; low and high end bracket the measured number.
By their numbers in this assay, from the lowest: compound 1; then compounds 3 and 2 (each within the scatter of the next).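

In this assay, methyl on the amide-type nitrogen gives a 1.1-fold lower number from compound 2 to compound 3 (0.03 log units; within the scatter), so this nitrogen accepts the added methyl without a readable change in the number. Methylcarbamoyl in place of bromo still gives a 4.5-fold higher number from compound 1 to compound 3 (0.65 log units; beyond the scatter), which means the methyl does not close the gap to the bromo compound. No measured evidence accounts for either result. Still open, going by these compounds, is whether a longer chain on this nitrogen, such as ethyl or benzyl, would be accepted as well. Also open, on these data alone, is how a carboxylic acid or an amine would compare in place of the amide.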